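The source may report more compounds than this note shows. Statements on the series, on what has been measured and on what is new or still open speak of the compounds shown alone.

Measured so far:
compound 1, `COc1cc(OC)c(C(=O)/C=C/c2ccc(Cl)cc2)c(OC)c1` — 0.2%
compound 2, `COc1cc(OC)c(C(=O)/C=C/c2ccc(Br)cc2)c(OC)c1` — 0.4%
compound 3, `COc1cc(O)c(C(=O)/C=C/c2ccccc2SC)c(OC)c1` — 31%

All three were tested in a functional assay on PC-3 cells (Homo sapiens), read by fluorescence and BrdU incorporation, with a stated time of 48 h, tested at 25 uM; a higher number here means a weaker effect of the compound at the concentration tested, a lower number a stronger effect. Compound 2 stands second highest of the three numbers; its nearest neighbour is compound 1, and the gap between them, a number 0.2 percentage points higher from compound 1 to compound 2 (within the scatter), comes from a bromo in place of a chloro on an aromatic carbon. Compound 3 stands far apart from both, since compound 3 gives 31% in this assay while compound 2 gives 0.4%; compound 3 differs from compound 2 in more than one place, so that gap cannot be tied to a single change.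

The next compound, compound 4, `COc1cc(OC)c(C(=O)/C=C/c2ccccc2)c(OC)c1`, is not yet measured. Compared with compound 2 the change is hydrogen in place of bromo on an aromatic carbon. Among the compounds with values here, the only measured step at that place is the halogen swap from compound 1 to compound 2, and it stayed within the scatter; no measured step removes a group from that carbon altogether, so the data give no direct guide to the size of this step. Given that compound 1 and compound 2 both sit close to the floor of the scale, compound 4 is expected to stay near that floor as well, with a step of a number 4.6 percentage points higher from compound 2 to compound 4 (within the scatter) that may or may not leave the scatter. The estimate for compound 4 in this assay is 5%, within a range from 0% to 25%.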

Compound 4, a percentage reported as activity, at one concentration (the size of the read-out at that concentration, not a potency): 1.7%
For compound 4 the middle estimate is 3.3 percentage points above the measured one; low and high end bracket the measured number.
By their numbers in this assay, from the lowest: compounds 1, 2 and 4 (each within the scatter of the next); then compound 3.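

In this assay, removing the halogen altogether gives a number 1.3 percentage points higher from compound 2 to compound 4 (within the scatter) when hydrogen replaces bromo and a number 1.5 percentage points higher from compound 1 to compound 4 (within the scatter) when hydrogen replaces chloro. This goes beyond the earlier swap of one halogen for another: among compounds 1, 2 and 4, a halogen on this aromatic carbon makes no difference that can be told from the scatter, and the plain phenyl of compound 4 serves as well as the 4-bromophenyl of compound 2 at this single concentration. No separate measurement is available that would help explain this result.

All three of these compounds sit near the low end of the scale at one concentration, so this read-out cannot show whether they would separate at lower concentrations, and it remains open whether a very different group on this carbon, such as an amine, a carboxylic acid or a longer alkyl chain, would leave the number in the same place. The much higher number for compound 3 also stays unexplained, since it differs from these compounds in more than one place and no single change can account for it.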